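A few compounds are considered here, and "the series" means these few. Any claim that something is new, unique, unknown or untested is made for them only; others in the source may bear on it.

Measured so far:
compound 1, `CCCC[C@]1(CC)CS(=O)(=O)c2ccc(OC)cc2[C@@H](c2ccccc2)[C@H]1O`: 55 nM
compound 2, `CCCC[C@]1(CC)CS(=O)(=O)c2ccc(NO)cc2[C@@H](c2ccccc2)[C@H]1O`: 260 nM

Both compounds share one core and differ only on the aromatic ring. In an assay on cells for inhibition of ileal sodium/bile acid cotransporter (Homo sapiens) (a higher number here means a weaker inhibitor, a lower number a stronger inhibitor), compound 1 gives 55 nM, while compound 2 gives 260 nM; the step of a 4.7-fold higher number from compound 1 to compound 2 (0.67 log units; beyond the scatter) is the only one measured here, so compound 2 stands as the higher of the two numbers.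

Compound 3, `CCCC[C@]1(CC)CS(=O)(=O)c2ccc(NC(=O)OCc3ccccc3)cc2[C@@H](c2ccccc2)[C@H]1O`, has not yet been measured. It differs from compound 2 by benzyloxycarbonyl in place of hydroxy on a nitrogen on an aromatic ring. Among the compounds with values here, no measured step changes the group on that nitrogen: the one known step swapped the whole group on the aromatic carbon, so it tells little about this change. Within the data shown here, with one step of modest size to lean on and no direct precedent, a change in this assay is expected that stays modest, more likely downward than upward: the expected step is a 2.2-fold lower number from compound 2 to compound 3 (0.34 log units; beyond the scatter). Compound 3 is therefore estimated at 120 nM, within a range of 30 nM to 500 nM.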

Compound 3, half-maximal inhibitory concentration: 400 nM
Compound 3: the middle estimate sits 3.3-fold (0.52 log units) below what was measured, and the stated range covers the measured number.
By their numbers in this assay, from the lowest: compound 1; then compounds 2 and 3 (each within the scatter of the next).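

In this assay, benzyloxycarbonyl in place of hydroxy on the nitrogen gives a 1.5-fold higher number from compound 2 to compound 3 (0.19 log units; within the scatter), so a far larger group carrying a six-membered aromatic ring is accepted there about as well as the single hydroxy oxygen. Going back to the methoxy group, (benzyloxycarbonyl)amino in place of methoxy on the aromatic carbon gives a 7.3-fold higher number from compound 1 to compound 3 (0.86 log units; beyond the scatter), so neither of the two nitrogen-linked groups shown matches methoxy at this place on the ring. No supporting data are available to explain these numbers.

From the compounds shown here alone, it remains open whether a plain amine or an acetamide on this aromatic carbon would come closer to methoxy. A methyl carbamate, which keeps the carbonyl but has no benzyl ring, would show how much that ring contributes.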